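The source may report more compounds than this note shows. Statements on the series, on what has been measured and on what is new or still open speak of the compounds shown alone.

Compound 1 `COc1ccc2c(=O)c(/C=C/C(=O)NCc3cccc(F)c3)coc2c1` was tested in a functional assay on L02 cells (Homo sapiens) for inhibition, read by MTT assay, with a stated time of 48 h; on this read-out higher numbers stand for weaker inhibition and lower numbers for stronger inhibition. In this assay compound 1 gives only a limit, > 200000 nM. Compound 2 `Cc1ccc(CNC(=O)/C=C/c2coc3cc(O)ccc3c2=O)cc1` likewise gives only a limit in this assay, > 200000 nM. Compound 1 thus stands at the limit of > 200000 nM in this assay, at which 2 of the 2 values shown sit, with no number to place it. Compound 3 `COc1ccc2c(=O)c(/C=C/C(=O)Nc3ccc(Cl)cc3)coc2c1` carries 4-chlorophenyl in place of 3-fluorobenzyl on an amide-type nitrogen. Among the measured compounds shown here, with no measured step between compounds to lean on, the change from compound 1 to compound 3 is expected to stay within the scatter, a number no higher from compound 1 to compound 3 (the limit leaves the size open). Compound 3 is therefore expected to give about 200000 nM, between 60000 nM and 400000 nM, most likely again only as a limit.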

Compound 3, half-maximal inhibitory concentration: > 200000 nM
Compound 3: a limit, no number (the forecaster's own chance of this, stated with the estimate: 80%); the middle value lies on the limit itself.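

Among the compounds shown here, compound 3 gives only a limit in this assay, as compound 1 does, so no step between compound 1 and compound 3 can be read. The compounds shown all sit at one limit: the limit of > 200000 nM in this assay, at which 3 of the 3 values shown sit.

What remains open is how strongly, if at all, any of these compounds inhibits, and which change to their structure would bring a measurable number.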